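The source may report more compounds than this note shows. Statements on the series, on what has been measured and on what is new or still open speak of the compounds shown alone.

Of the compounds shown here, two have numbers so far in a physicochemical assay for solubility, at pH 7.4; a higher number here means a more soluble compound, a lower number a less soluble compound. Compound 1 `COc1ccc(NC(=O)Nc2cc(C)nc3ccccc23)cc1Cl` gives 400 nM, and compound 2 `Cc1cc(NC(=O)Nc2ccc(N)cc2)c2ccccc2n1` gives 18500 nM. Compound 2 therefore holds the higher of the two numbers, and the gap between them lies beyond the scatter. Compound 3 `Cc1cc(NC(=O)Nc2cccc(Cl)c2)c2ccccc2n1` keeps the shared core and differs from compound 2 in one place, with 3-chlorophenyl in place of 4-aminophenyl on an amide-type nitrogen. For the measured compounds named here, no measured pair isolates such a change, so the expectation rests on these two values alone. With the 4-aminophenyl gone, compound 3 is expected to fall towards compound 1 at 400 nM in this assay. The expected change is a downward step beyond the scatter, a 21-fold lower number from compound 2 to compound 3 (1.31 log units; beyond the scatter). Compound 3 is estimated at 900 nM, with an expected range of 250 nM to 3500 nM.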

Compound 3, solubility: 800 nM
Compound 3: the middle estimate sits 1.1-fold (0.05 log units) above what was measured, and the stated range covers the measured number.
By their numbers in this assay, from the lowest: compounds 1 and 3 (each within the scatter of the next); then compound 2.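

In this assay, for the compounds shown here, 3-chlorophenyl in place of 4-aminophenyl on an amide-type nitrogen gives a large drop, a 23-fold lower number from compound 2 to compound 3 (1.36 log units; beyond the scatter), the first reading of a single change at this position. Hydrogen in place of methoxy on an aromatic carbon, by contrast, gives a 2.0-fold higher number from compound 1 to compound 3 (0.30 log units; within the scatter), so this change cannot be told apart from the scatter, and compound 3 stays level with compound 1 despite that difference. Nothing available explains the large step.

The compounds shown leave open whether that step follows the loss of the amine or the arrival of the chlorine, as both change together. As far as these compounds go, a plain phenyl on the same nitrogen would separate the two, and a carboxylic acid or a longer chain carrying an amine on that ring remains untested in the compounds here.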